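Dichlorinated thiophene variant in a weakly active series

The compounds below may be only part of what the source reports. "The series", "measured", "known", "first", "only" and "open" are said of these compounds alone.

Of the compounds shown here, two have numbers so far. Among the measured compounds shown here, compound 1 `N=C(N)N/N=C/c1c(-c2cccs2)nc2n1CCS2` is the first; in a functional assay on cells (Cancer cell lines, Homo sapiens) for inhibition (on this read-out higher numbers stand for weaker inhibition of growth and lower numbers for stronger inhibition of growth), compound 1 gives 19500 nM. Compound 2 `N=C(N)N/N=C/c1c(-c2ccsc2)nc2sccn12` is the second; in this assay compound 2 gives 14800 nM. These two values lie within the usual scatter of each other, so compound 1 stands at the same weak level as compound 2 rather than apart from it, and neither can be called the more active. Compound 3 `N=C(N)N/N=C/c1c(-c2cc(Cl)sc2Cl)nc2n1CCS2` has not been measured. It differs from compound 1 by 2,5-dichlorothiophen-3-yl in place of thiophen-2-yl on an aromatic carbon. No measured pair in this set carries this change, so nothing shown tells its direction; the expectation is a step no larger than the scatter, with either sign possible. The expected step is a 1.2-fold lower number from compound 1 to compound 3 (0.09 log units; within the scatter). Compound 3 is accordingly estimated at 16000 nM, with a range from 5000 nM to 45000 nM.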

Compound 3, concentration for 50% growth inhibition: 8130 nM
Estimate against measurement, compound 3: 2.0-fold (0.29 log units) above; measured number inside the range.
By their numbers in this assay, from the lowest: compounds 3, 2 and 1 (each within the scatter of the next, the first and the last beyond it).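

Among the compounds shown here, on the aromatic carbon of the five-membered aromatic ring with 2 nitrogen, this change gives the first step that lies beyond the scatter: in this assay, 2,5-dichlorothiophen-3-yl in place of thiophen-2-yl gives a 2.4-fold lower number from compound 1 to compound 3 (0.38 log units; beyond the scatter). The position thus accepts a thiophene carrying two chlorine atoms and responds to it with a modest move toward stronger inhibition of growth. Nothing available gives a reason for this step.

Still open, on these data alone, is whether the step belongs to the two chlorine atoms or to the change in how the thiophene is attached, as this single pair carries both differences. Also open, as far as these compounds go, is how the position responds to a group of another kind, such as an amine or a carboxylic acid, in place of the thiophene.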